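Amine oxidase B series: sulfonyl for chlorobenzyl, longer linker

A few compounds are considered here, and "the series" means these few. Any claim that something is new, unique, unknown or untested is made for them only; others in the source may bear on it.

Compound 1 `C[C@H](NCc1ccc(OCCCCN2CCN(c3cccc4c3ccn4Cc3cccc(Cl)c3)CC2)cc1)C(N)=O` was tested in an assay on BTI cells for inhibition of Amine oxidase [flavin-containing] B (Homo sapiens), read by fluorescence, with stated times of 30 min and 1 h; a higher number here means a weaker inhibitor, a lower number a stronger inhibitor. In this assay compound 1 gives only a limit, > 1000 nM. Compound 2 `C[C@H](NCc1ccc(OCCCCCN2CCN(c3cccc4c3ccn4Cc3cccc(Cl)c3)CC2)cc1)C(N)=O` differs from compound 1 in its core, and that difference is not broken down here. In this assay compound 2 gives only a limit, > 1000 nM. Compound 3 `C[C@H](NCc1ccc(OCCCCN2CCN(c3cccc4c3ccn4S(=O)(=O)c3ccccc3)CC2)cc1)C(N)=O` carries phenylsulfonyl in place of 3-chlorobenzyl on an aromatic nitrogen. In this assay compound 3 gives only a limit, > 1000 nM. The step that the two limits leave unreadable from compound 1 to compound 3 cannot be sized because of the limit of > 1000 nM in this assay, at which 3 of the 3 values shown sit. Compound 4 `C[C@H](NCc1ccc(OCCCCCN2CCN(c3cccc4c3ccn4S(=O)(=O)c3ccccc3)CC2)cc1)C(N)=O` is not yet measured and carries the same change relative to compound 2, namely (phenylsulfonyl in place of 3-chlorobenzyl on an aromatic nitrogen). The step from compound 2 to compound 4 is expected to be a step that the limit leaves unreadable from compound 2 to compound 4, resting on compound 1, compound 2 and compound 3 all sitting at the limit of > 1000 nM in this assay, at which 3 of the 3 values shown sit. For compound 4 the estimate in this assay is 3000 nM, expected between 1000 nM and 20000 nM, most probably reported again as a limit only.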

Compound 4, half-maximal inhibitory concentration: > 1000 nM
Compound 4 gave a limit, no number; the forecaster's own chance of this, stated with the estimate: 85%; the middle value lies beyond the limit too.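

Among these compounds, no step can be sized from compound 2 to compound 4, because both compounds sit at the same limit: the limit of > 1000 nM in this assay, at which 4 of the 4 values shown sit. The compounds shown leave open how strongly any of them inhibits, and whether phenylsulfonyl in place of 3-chlorobenzyl changes inhibition at all.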